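The source may hold more compounds than are shown below. What is called first, only, known or untested is meant among the compounds shown, and "the series" means these compounds.

The measured compounds:
compound 1, `O=C(C1CCC1)N1CC2CC(C1)N2`, gives 80% in an assay on CHO cells for agonist activity at Neuronal acetylcholine receptor; alpha3/alpha6/beta2/beta3 (Homo sapiens), read by FLIPR and calcium flux; a lower number here means a smaller maximal response, a higher number a larger maximal response;
compound 2, `O=C(C1CC=CC1)N1CC2CC(C1)N2`, gives 99%;
compound 3, `O=C([C@H]1C[C@H]1F)N1CC2CC(C1)N2`, gives 130%.

Compound 3 gives the highest response of the three in this assay, its gaps to compound 2 and to compound 1 both lying beyond the scatter. Among the compounds with values here, the only measured step that bears on the next change is a number 50 percentage points higher from compound 1 to compound 3 (beyond the scatter), a large gain; yet that step swapped the whole ring and brought the fluoro in at once, so it speaks to the present change only loosely. Compound 4, `C[C@@H]1C[C@@H]1C(=O)N1CC2CC(C1)N2`, differs from compound 3 in one place: methyl in place of fluoro on a saturated ring carbon. Within the data shown here, no measured step swaps fluoro for methyl, so a moderate fall is expected rather than a further rise. For compound 4 the expected value in this assay is 110%, within 85% to 135%. This amounts to an expected step of a number 20 percentage points lower from compound 3 to compound 4 (beyond the scatter).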

Compound 4, largest response reached (Emax), in percent of the reference or control that the assay uses: 87%
Beside the measured number, compound 4's estimate is 23 percentage points above it; the measured number falls inside the stated range.
By their numbers in this assay, from the lowest: compounds 1 and 4 (each within the scatter of the next); then compound 2; then compound 3.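

Putting methyl in place of fluoro on this saturated ring carbon gives a number 43 percentage points lower from compound 3 to compound 4 (beyond the scatter) in this assay, so the three-membered ring alone does not carry the high response of compound 3. The change of ring with methyl on it gives a number 7 percentage points higher from compound 1 to compound 4 (within the scatter), which ties the large gain seen for compound 3 to the fluoro among these compounds. Nothing shown here explains why the fluoro has this effect.

As far as these compounds go, whether chloro, hydroxyl or nitrile on the same ring carbon would keep the response of compound 3 remains open.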